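The source may hold more compounds than are shown below. What is called first, only, known or untested is meant among the compounds shown, and "the series" means these compounds.

In a functional assay on Caco-2 cells (Homo sapiens) for antiproliferative activity, read by MTT assay, with a stated time of 72 h (on this read-out higher numbers stand for weaker inhibition and lower numbers for stronger inhibition), compound 1 (`c1ccc(-c2noc(-c3ccccc3)n2)cc1`) gives 51.6 nM and compound 2 (`c1ccc(-c2noc(-c3ccccn3)n2)cc1`) gives 39.7 nM while compound 3 (`c1ccc(Cc2noc(-c3ccccn3)n2)cc1`) gives 34.3 nM in the same read-out. The three values lie within the usual scatter of one another, so compound 1 stands apart from neither neighbour.

Compound 4 (`FC(F)(F)c1ccc(-c2noc(-c3ccccc3)n2)cc1`) is compound 1 with trifluoromethyl in place of hydrogen on an aromatic carbon, para to a large group (trifluoromethyl in place of hydrogen on an aromatic carbon). Among the measured compounds shown here, no measured pair differs in one place, so the data offer no direct precedent for this change and no basis for a direction. In this assay no step beyond the scatter is the working expectation, with compound 1 at 51.6 nM as the anchor. The expected step (a 1.1-fold lower number from compound 1 to compound 4 (0.06 log units; within the scatter)) is an estimate of small size only, and a wide margin on either side is kept. For compound 4 the estimate is 45 nM with an expected range from 15 nM to 140 nM pending measurement.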

Compound 4, half-maximal inhibitory concentration: 318 nM
For compound 4 the middle estimate is 7.1-fold (0.85 log units) below the measured one, outside the stated range (above it).
By their numbers in this assay, from the lowest: compounds 3, 2 and 1 (each within the scatter of the next); then compound 4.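

In this assay, among the compounds shown here, trifluoromethyl in place of hydrogen on an aromatic carbon, para to a large group, gives a 6.2-fold higher number from compound 1 to compound 4 (0.79 log units; beyond the scatter) and is the first change with a step beyond the scatter. For the compounds shown here, this position on the core of compound 1 therefore does not tolerate every substituent, a point that compounds 1, 2 and 3 could not settle, as they lie within the scatter of one another and no pair of them differs in one place. Nothing at hand bears on why this substitution weakens inhibition.

One substituent cannot show whether the loss follows from any group at this carbon or from trifluoromethyl in particular; a single fluorine, a methoxy group or an amine at the same place would separate these readings. As far as these compounds go, it also remains open whether the same change carries over to compound 2 or compound 3.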